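Working notes: 3-nitrophenyl in place of 4-nitrophenyl

The source may hold more compounds than are shown below. What is called first, only, known or untested is meant among the compounds shown, and "the series" means these compounds.

compound 1 `COc1ccc(NC(=O)NCCNS(=O)(=O)c2ccc(-c3ccccc3OCc3ccccc3)s2)cc1`: > 50000 nM
compound 2 `COc1cccc(NC(=O)NCCNS(=O)(=O)c2ccc(-c3ccccc3OCc3ccccc3)s2)c1`: 1700 nM
compound 3 `O=[N+]([O-])c1ccc(NC(=S)NCCNS(=O)(=O)c2ccc(-c3ccccc3OCc3ccccc3)s2)cc1`: > 50000 nM

All three results come from a functional assay on HL-60 cells (Homo sapiens) for inhibition, read by CCK-8 assay, with a stated time of 48 h; a higher number here means a weaker inhibitor, a lower number a stronger inhibitor. In this assay compound 3 gives > 50000 nM, which is a limit and not a number. Compound 1 gives > 50000 nM, also a limit. Compound 3 therefore stands at the limit of > 50000 nM in this assay, at which 2 of the 3 values shown sit.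

The next structure is compound 4 `O=[N+]([O-])c1cccc(NC(=S)NCCNS(=O)(=O)c2ccc(-c3ccccc3OCc3ccccc3)s2)c1`, and the change is 3-nitrophenyl in place of 4-nitrophenyl on an amide-type nitrogen. In words, 3-nitrophenyl replaces 4-nitrophenyl on an amide-type nitrogen whose other neighbours are: thiocarbonyl carbon. The two compounds have the same atoms, joined differently.

The closest measured step is the matching swap of 3-methoxyphenyl for 4-methoxyphenyl, an at least 29-fold lower number from compound 1 to compound 2 (1.46 log units; beyond the scatter). Going by the values given here, this step is large, but it is the only such swap measured, and it carries a different group on a different linker. The step of an at least 29-fold higher number from compound 2 to compound 3 (1.46 log units; beyond the scatter) is also large, and it shows that the group on the amine nitrogen matters, while a step that the two limits leave unreadable from compound 1 to compound 3 can't be read. A large move to a lower number is therefore expected, with much uncertainty, and a second limit for this pair remains possible. The expected step is an at least 8.3-fold lower number from compound 3 to compound 4 (0.92 log units; beyond the scatter). For compound 4 the estimated value is 6000 nM, with an expected range of 800 nM to 50000 nM.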

Compound 4, half-maximal inhibitory concentration: > 50000 nM
Compound 4 gave a limit, no number; the forecaster's own chance of this, stated with the estimate: 35%; at least 8.3-fold (0.92 log units) between middle value and limit.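

In this assay compound 4 gives > 50000 nM, which is a limit of the assay and not a number. Going by these compounds alone, the swap to the 3-substituted ring that gave an at least 29-fold lower number from compound 1 to compound 2 (1.46 log units; beyond the scatter) in the methoxyphenyl pair yields no measurable value in the nitrophenyl pair, so a readable gain from this change is so far confined to that one pair, and compound 2 remains the only compound with a number, with an at least 29-fold higher number from compound 2 to compound 4 (1.46 log units; beyond the scatter) marking a large gap to the new compound. The steps to compound 4 from compound 3 and from compound 1 cannot be read, and the new result extends the cluster of limits in the series: the limit of > 50000 nM in this assay, at which 3 of the 4 values shown sit.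

Compound 2 and compound 4 differ in both the ring substituent and the thiocarbonyl carbon, so the compounds shown leave open which of the two changes separates them, and a 3-methoxyphenyl group on the thiocarbonyl nitrogen or a 3-nitrophenyl group on the carbonyl nitrogen would divide that gap. Also open, from the compounds shown here alone, is how other groups at the 3-position of this ring would read, such as an amine, a carboxylic acid or a halogen atom.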